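Methoxy for fluoro on the aryl ketone of a boron-bearing chalcone

The source may report more compounds than this note shows. Statements on the series, on what has been measured and on what is new or still open speak of the compounds shown alone.

Of the compounds shown here, three built on a shared core have been measured in a functional assay on SK-OV-3 cells (Homo sapiens) for cytotoxicity, read by MTT assay, with a stated time of 48 h; on this read-out higher numbers stand for weaker inhibition and lower numbers for stronger inhibition. Compound 1 `O=C(/C=C/c1ccc2c(c1)B(O)OC2)c1ccc(I)cc1` gives 4200 nM, compound 2 `Cc1ccc(C(=O)/C=C/c2ccc3c(c2)B(O)OC3)cc1` gives 3700 nM, and compound 3 `O=C(/C=C/c1ccc2c(c1)B(O)OC2)c1cccc(F)c1` gives 4800 nM. The number for compound 3 sits at the upper edge of this set, yet a 1.1-fold higher number from compound 1 to compound 3 (0.06 log units; within the scatter) and a 1.3-fold higher number from compound 2 to compound 3 (0.11 log units; within the scatter) both fall within the scatter, so the three compounds cannot be told apart on these data.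

Compound 4 `COc1cccc(C(=O)/C=C/c2ccc3c(c2)B(O)OC3)c1` differs from compound 3 in one place: methoxy in place of fluoro on an aromatic carbon. The three steps already seen all exchange one group on the aromatic ring attached to the carbonyl, and none of them left the scatter, as a 1.1-fold lower number from compound 1 to compound 2 (0.06 log units; within the scatter) shows for a swap on the same ring. Within the data shown here, nothing among the measured compounds points to a change beyond the scatter for a further swap of this kind.

Compound 4 is therefore expected to give about 4500 nM in this assay, with a likely range from 2000 nM to 10000 nM. The step this estimate implies, a 1.1-fold lower number from compound 3 to compound 4 (0.03 log units; within the scatter), is expected to stay within the scatter.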

Compound 4, half-maximal inhibitory concentration: 2600 nM
Compound 4: the middle estimate sits 1.7-fold (0.24 log units) above what was measured; the measured number falls inside the stated range.
By their numbers in this assay, from the lowest: compounds 4, 2, 1 and 3 (each within the scatter of the next).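

Among these compounds, compounds 3 and 4 are the first pair here in which the group on the aromatic carbon meta to a large group is exchanged while the rest of the molecule stays the same. In this assay, replacing fluoro (1 heavy atom, 0 hydrogen-bond acceptors) with methoxy (2 heavy atoms, 1 hydrogen-bond acceptor) gives a 1.8-fold lower number from compound 3 to compound 4 (0.27 log units; within the scatter), the widest step printed for this series, though it still does not separate the two compounds. Nothing shown here bears on what lies behind the size of this step.

The compounds shown leave open whether an amine, a carboxylic acid or a longer chain such as ethoxy at this same place would carry the number in this assay beyond the scatter. They also leave open whether methoxy would give a comparable number at the place held by iodo in compound 1 and by methyl in compound 2, so this single exchange cannot yet be read as a trend for the ring as a whole.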